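Bromo Added Ortho on a Benzyl Ring of a Chalcone

A few compounds are considered here, and "the series" means these few. Any claim that something is new, unique, unknown or untested is made for them only; others in the source may bear on it.

Compound 1 `O=C(/C=C/c1ccc(OCc2cn(Cc3ccccc3)nn2)cc1)c1ccc(Br)cc1` and compound 2 `O=C(/C=C/c1ccc(OCc2cn(Cc3cccc(Br)c3)nn2)cc1)c1ccc(Br)cc1` were both tested in a functional assay on MIA PaCa-2 cells (Homo sapiens) for inhibition, read by MTT assay, with a stated time of 48 h, tested at 10 uM; on this read-out lower numbers stand for less inhibition of growth and higher numbers for more inhibition of growth at the one concentration tested. Compound 1 gives 44%, and compound 2 gives 43%; the change between them, (bromo in place of hydrogen on an aromatic carbon), made a step of a number 1 percentage points lower from compound 1 to compound 2 (within the scatter). Compound 3 `COc1ccc(C(=O)/C=C/c2ccc(OCc3cn(Cc4ccccc4)nn3)cc2)cc1` differs from compound 1 in its core by methoxy in place of bromo on an aromatic carbon, and in this assay compound 3 gives 68%, a step of a number 24 percentage points higher from compound 1 to compound 3 (beyond the scatter), leaving compound 3 with the highest number of the three.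

Compound 4 `COc1ccc(C(=O)/C=C/c2ccc(OCc3cn(Cc4ccccc4Br)nn3)cc2)cc1` has not yet been measured. It differs from compound 3 by bromo in place of hydrogen on an aromatic carbon. This is the same kind of change as that from compound 1 to compound 2, but the place is not identical: in compound 2 the bromo sits meta to a large group, while in compound 4 it sits ortho to a large group.

Because the earlier step of a number 1 percentage points lower from compound 1 to compound 2 (within the scatter) was within the scatter, compound 4 is expected to move only a number 3 percentage points lower from compound 3 to compound 4 (within the scatter) from compound 3. Compound 4 is therefore estimated at 65%, between 50% and 80%.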

Compound 4, percent growth inhibition at one concentration: 50%
Estimate against measurement, compound 4: 15 percentage points above, and the stated range covers the measured number.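

The step of a number 18 percentage points lower from compound 3 to compound 4 (beyond the scatter) in this assay shows that the change from benzyl to 2-bromobenzyl lowered the number on the core of compound 3, whereas the bromo added in compound 2 had left the number within the scatter. Adding a bromo to this benzyl ring therefore did not carry over unchanged from one core to the other: the same change on two cores in this assay, a number 1 percentage points lower (within the scatter) from compound 1 to compound 2 and a number 18 percentage points lower (beyond the scatter) from compound 3 to compound 4, 17 percentage points apart, beyond the scatter of two such steps. What this does not show is whether the gap belongs to the core or to the place of the bromo, which stands ortho to a large group in compound 4 but not in compound 2; the two pairs differ in both respects, and one pair on each core cannot separate them.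

The compounds shown leave open how the 2-bromobenzyl group behaves on the core of compound 1, and how a bromo placed as in compound 2 behaves on the core of compound 3. Also open, going by these compounds, is whether a chloro, a methyl or an amine on the benzyl ring would give a step of the same kind.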